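Trading carboxy for ethyl on a flexible side chain

The source may report more compounds than this note shows. Statements on the series, on what has been measured and on what is new or still open speak of the compounds shown alone.

Compound 1 `CNC(=O)C[C@@H]1C[C@@H](c2ccc(Cl)c(Cl)c2)[C@H](NC(=O)c2cc(-c3c(Cl)cnn3C)c(Cl)o2)CN1`: 2.64 nM
Compound 2 `Cn1ncc(Cl)c1-c1cc(C(=O)N[C@@H]2CN[C@H](CCCO)C[C@H]2c2ccc(Cl)c(Cl)c2)oc1Cl`: 2.56 nM
Compound 3 `Cn1ncc(Cl)c1-c1cc(C(=O)N[C@@H]2CN[C@H](CC(=O)O)C[C@H]2c2ccc(Cl)c(Cl)c2)oc1Cl`: 1.94 nM

These three compounds were tested in an assay for inhibition of RAC-alpha serine/threonine-protein kinase (Homo sapiens), read by HTRF, with a stated time of 1 h; on this read-out lower numbers stand for stronger inhibition and higher numbers for weaker inhibition. Compound 3 gives the lowest number, but its neighbours sit within the scatter: a 1.4-fold lower number from compound 1 to compound 3 (0.13 log units; within the scatter) and a 1.3-fold lower number from compound 2 to compound 3 (0.12 log units; within the scatter), and likewise a 1.0-fold lower number from compound 1 to compound 2 (0.01 log units; within the scatter). Three quite different groups on the same chain carbon therefore give the same outcome.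

Compound 4 `CCC[C@@H]1C[C@@H](c2ccc(Cl)c(Cl)c2)[C@H](NC(=O)c2cc(-c3c(Cl)cnn3C)c(Cl)o2)CN1` carries the change (ethyl in place of carboxy on a saturated chain carbon bound to a saturated ring carbon). Among the compounds with values here, no measured step removes every donor and acceptor from this chain, so the expectation rests on the tolerance seen above. A small or no step beyond the scatter is expected, a 1.8-fold higher number from compound 3 to compound 4 (0.26 log units; within the scatter), leaning weaker. Compound 4 is estimated at 3.5 nM, between 1.2 nM and 10 nM.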

Compound 4, half-maximal inhibitory concentration: 10.4 nM
Compound 4: middle estimate off by 3.0-fold (0.47 log units), on the low side; the measured number lies above the stated range.
By their numbers in this assay, from the lowest: compounds 3, 2 and 1 (each within the scatter of the next); then compound 4.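

Unlike the swaps among the earlier chains, replacing carboxy with ethyl (a 5.4-fold higher number from compound 3 to compound 4 (0.73 log units; beyond the scatter)) moves the number beyond the scatter. Hydrogen in place of hydroxy (a 4.1-fold higher number from compound 2 to compound 4 (0.61 log units; beyond the scatter)) and ethyl in place of methylcarbamoyl (a 3.9-fold higher number from compound 1 to compound 4 (0.60 log units; beyond the scatter)) do the same, so the three oxygen-bearing chains stand apart from the plain propyl chain of compound 4. No available evidence explains this gap. From the compounds shown here alone, whether an amine on this chain would match the oxygen-bearing groups remains open, as does the effect of a longer plain carbon chain.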